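Methoxy added to the benzoyl group of compound 1

A few compounds are considered here, and "the series" means these few. Any claim that something is new, unique, unknown or untested is made for them only; others in the source may bear on it.

For the measured compounds named here, in a functional assay on DU-145 cells (Homo sapiens) for inhibition, read by sulforhodamine B assay, with a stated time of 48 h (a lower number here means a stronger inhibitor of growth, a higher number a weaker inhibitor of growth), compound 1 (`O=C(NNC(=O)c1ccc2[nH]c(-c3ccc([N+](=O)[O-])o3)nc2c1)c1ccccc1`) gives 15.6 ug/mL and stands lowest of the two numbers so far. Compound 2 (`COc1cc(C(=O)NNC(=O)c2ccc3[nH]c(-c4ccc([N+](=O)[O-])s4)nc3c2)cc(OC)c1OC`) gives 62.5 ug/mL as the higher number, a gap beyond the scatter. Compound 3 (`COc1cccc(C(=O)NNC(=O)c2ccc3[nH]c(-c4ccc([N+](=O)[O-])o4)nc3c2)c1`) keeps the core of compound 1 and changes in one place, phenyl to 3-methoxyphenyl (methoxy in place of hydrogen on an aromatic carbon). Going by the values given here, no measured step isolates this change. Expected is a small step toward weaker growth inhibition, a 1.6-fold higher number from compound 1 to compound 3 (0.20 log units; within the scatter) in this assay and within the scatter. For compound 3 the estimated value is 25 ug/mL (expected range 8 ug/mL to 70 ug/mL).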

Compound 3, concentration for 50% growth inhibition: 15.6 ug/mL
Beside the measured number, compound 3's estimate is 1.6-fold (0.20 log units) above it; the measured number falls inside the stated range.
By their numbers in this assay, from the lowest: compounds 1 and 3 (each within the scatter of the next); then compound 2.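

In this assay, for the compounds shown here, the step of no change at the digits printed from compound 1 to compound 3 (within the scatter) gives the first single-place reading: methoxy in place of hydrogen on the six-membered aromatic ring, meta to a large group. At this position, phenyl to 3-methoxyphenyl is tolerated on the core of compound 1. No measurement available here bears on the reason for this result.

On these data alone, whether an amine, a carboxylic acid or a longer chain such as butoxy would be tolerated at the same position remains open. So does the reading of methoxy elsewhere on this ring.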